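Swapping chloro for nitro: an expected shift in lipophilicity

This account rests on a few compounds, and the source may have more. Where it says the series, first, only, none or still open, it means among the compounds named here.

Four compounds form a small set built on two cores. Compound 1 `Clc1cccc(-c2nc3ccccc3[nH]2)c1` and compound 2 `O=[N+]([O-])c1cccc(-c2nc3ccccc3[nH]2)c1` share one core, and compound 3 `O=C(c1cccnc1)n1c(-c2ccccc2Cl)nc2ccccc21` and compound 4 `O=C(c1cccnc1)n1c(-c2ccccc2[N+](=O)[O-])nc2ccccc21` share another; how the two cores differ is not broken down here.

In a physicochemical assay for lipophilicity, measured as octanol-water partition (a lower number here means a more polar compound, a higher number a more lipophilic compound), compound 1 gives 3.63, and compound 2 gives 3.07. The change between them, (nitro in place of chloro on an aromatic carbon), made the step of a number 0.56 log units lower from compound 1 to compound 2 (beyond the scatter). In this assay compound 3 gives 4.7, the highest number among the three measured compounds.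

Compound 4 has not yet been measured in this assay. It differs from compound 3 by nitro in place of chloro on an aromatic carbon. Within the data shown here, this is the same kind of change as the one from compound 1 to compound 2, but not the same: in the first pair the nitro group stands meta to a group of 9 heavy atoms, whereas in the second pair it stands ortho to a large group.

Resting on the step from compound 1 to compound 2 as the only example, a step of similar size is expected from compound 3 to compound 4, namely a number 0.50 log units lower from compound 3 to compound 4 (beyond the scatter), with some allowance for the different surroundings of the place. On that basis, compound 4 is estimated to give 4.2 in this assay, expected to fall between 3.7 and 4.7.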

Compound 4, partition coefficient: 4.13
For compound 4 the middle estimate is 0.07 log units above the measured one; measured number inside the range.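

In this assay, putting nitro in place of chloro gave a number 0.57 log units lower from compound 3 to compound 4 (beyond the scatter) and this is close in size to a number 0.56 log units lower from compound 1 to compound 2 (beyond the scatter) even though the two pairs are built on different cores and in compound 4 the nitro stands ortho to a large group. So within these two pairs the change carried over from one core to the other with its size intact, which is what a medicinal chemist hopes for when reusing a step measured elsewhere in a series, but two pairs are too few to make this a rule for other cores or other places on the ring. Nothing shown here bears on why the two steps came out so alike, and their agreement could not by itself reveal a reason.

The compounds shown hold only chloro and nitro at this place, so it stays open whether an amine, a carboxylic acid or a methoxy group would also give steps of matching size on both cores. On these data alone, it also stays open whether the nitro-for-chloro step would keep its size on a third core, or with the group on a different carbon of the ring.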